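The source may hold more compounds than are shown below. What is called first, only, known or untested is meant among the compounds shown, and "the series" means these compounds.

Compound 2 `O=C(COc1cccc2ccccc12)N/N=C/c1cccc(O)c1` sits at the top of the three numbers recorded in an ADME assay on MT4 cells (Homo sapiens) for cytotoxicity, read by MTT assay, with a stated time of 4 days; on this read-out higher numbers stand for lower toxicity in this test and lower numbers for higher toxicity in this test. In this assay compound 2 gives 32.6 ug/mL. Compound 1 `CCOc1ccc(/C=N/NC(=O)COc2cccc3ccccc23)cc1O` carries an ethoxy group and a hydroxyl on its aryl ring, and in this assay compound 1 gives 6.23 ug/mL. Compound 3 `COc1ccc(/C=N/NC(=O)COc2cccc3ccccc23)cc1O` carries a methoxy group in place of that ethoxy, and in this assay compound 3 gives 7.05 ug/mL. The two measured steps that bear on the aryl ring are a 5.2-fold higher number from compound 1 to compound 2 (0.72 log units; beyond the scatter) and a 4.6-fold lower number from compound 2 to compound 3 (0.67 log units; beyond the scatter), both beyond the scatter, while a 1.1-fold higher number from compound 1 to compound 3 (0.05 log units; within the scatter) stays within it. So the record shows that a less substituted phenyl ring goes with a higher number, and that the size of the alkoxy group makes no difference that can be trusted.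

Compound 4 `O=C(COc1cccc2ccccc12)N/N=C/c1ccc(Br)cc1` is the next step from compound 2: 4-bromophenyl in place of 3-hydroxyphenyl on a carbon with a double bond to nitrogen. Among the compounds with values here, no measured step exchanges a hydroxyl for a bromine, so the expectation rests only on the observation that substitution on this ring lowered the number in this assay whenever it was seen. An analogous, if smaller, lowering is expected here, as a 1.8-fold lower number from compound 2 to compound 4 (0.26 log units; within the scatter). For compound 4 the estimate in this assay is 18 ug/mL, with a range from 5 ug/mL to 60 ug/mL.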

Compound 4, half-maximal cytotoxic concentration: 106 ug/mL
Compound 4: middle estimate off by 5.9-fold (0.77 log units), on the low side; the measured number lies above the stated range.
By their numbers in this assay, from the lowest: compounds 1 and 3 (each within the scatter of the next); then compound 2; then compound 4.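

In this assay the exchange of 3-hydroxyphenyl for 4-bromophenyl on a carbon with a double bond to nitrogen gives a 3.3-fold higher number from compound 2 to compound 4 (0.51 log units; beyond the scatter), so a higher number here stands for lower toxicity in this test, and the ring need not be left with a lone hydroxyl for the number to be high. The earlier reading, that a less substituted ring goes with a higher number, rested only on compounds that all carry a hydroxyl on this ring, and compound 4, the first without one, goes against any general form of it. No measurement is at hand that accounts for this rise, so its cause stays unknown.

The step removes the hydroxyl, brings in the bromine and moves the substituent all at once, so the compounds shown leave open which of these goes with the higher number. A plain phenyl ring, or a chlorine, an amine or a carboxylic acid in place of the bromine, would be needed to separate these changes.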